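Bromination of the fused core in compound 1

The source may hold more compounds than are shown below. What is called first, only, known or untested is meant among the compounds shown, and "the series" means these compounds.

Within the data shown here, compound 1 `CC(C)(C)c1ccc(-n2c(-c3cccnc3N)nc3cccnc32)cc1` gives 3900 nM in an in vitro assay on Sf9 cells for inhibition of RAC-alpha serine/threonine-protein kinase (Homo sapiens), read by AlphaScreen, with a stated time of 20 min (a higher number here means a weaker inhibitor, a lower number a stronger inhibitor), the highest of the two numbers so far; compound 2 `CC(=O)NCc1ccc(-n2c(-c3cccnc3N)nc3cccnc32)cc1`, the nearest neighbour, gives 810 nM. Among the measured compounds shown here, the only measured step, a 4.8-fold lower number from compound 1 to compound 2 (0.68 log units; beyond the scatter), concerns a different site of the molecule. Compound 3 `CC(C)(C)c1ccc(-n2c(-c3cccnc3N)nc3cc(Br)cnc32)cc1` carries bromo in place of hydrogen on an aromatic carbon. For the measured compounds named here, no measured step touches this position, so no direction can be read from the series. For compound 3 the expected step is a 1.3-fold lower number from compound 1 to compound 3 (0.11 log units; within the scatter), within the scatter. The estimate for compound 3 is 3000 nM, with a range from 800 nM to 10000 nM.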

Compound 3, half-maximal inhibitory concentration: > 300000 nM
Compound 3: only a limit was reported; the forecaster's own chance of this, stated with the estimate: 10%; middle value at least 100-fold (2.00 log units) away from the limit.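

Among these compounds, the bromo on this aromatic carbon, two atoms from the ring nitrogen, gives the first reading for a change on the shared core, and it is a large one in this assay: an at least 76-fold higher number from compound 1 to compound 3 (1.88 log units; beyond the scatter). The value of compound 3 is a limit and not a number: the limit of > 300000 nM in this assay, at which 1 of the 3 values shown sits. A single heavy atom at this place thus gives a larger step than the earlier tert-butyl to acetamidomethyl change at the other site.

On these data alone, whether this holds for bromo alone or for any group on this carbon stays open; fluoro, methyl or an amine here would separate the two. Also open, as far as these compounds go, is whether bromo has the same effect with the acetamidomethyl of compound 2.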